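Benzofuran ether series: step from compound 2 to compound 4

This account rests on a few compounds, and the source may have more. Where it says the series, first, only, none or still open, it means among the compounds named here.

Measured so far:
- compound 1 `COc1cc(OCc2ccccc2OCc2ccccc2)c2cc(-c3cn4nc(OC)sc4n3)oc2c1`: 2500 nM
- compound 2 `COc1cc(OCc2cccc(CCc3ccccc3)c2)c2cc(-c3cn4nc(OC)sc4n3)oc2c1`: 1200 nM
- compound 3 `COc1nn2cc(-c3cc4cccc(OC)c4o3)nc2s1`: 3500 nM

In an assay on a cell-free system (plasma) for antagonist activity at proteinase-activated receptor 4 (Homo sapiens), with a stated time of 5 min, in the presence of a further agent that is not named here (a higher number here means a weaker inhibitor, a lower number a stronger inhibitor), compound 2 gives the lowest number of the three, and its gaps to compound 1 and to compound 3 both lie beyond the scatter. Among the measured compounds shown here, no pair of measured compounds differs in a single place, so no measured step is at hand. Compound 4 `COc1cc(OCc2cccc(Sc3ccccc3)c2)c2cc(-c3cn4nc(OC)sc4n3)oc2c1` differs from compound 2 as follows: phenylsulfanyl in place of phenethyl on an aromatic carbon. For the measured compounds named here, with only three numbers and no comparable step, the expected change from compound 2 to compound 4 in this assay is a 1.3-fold higher number from compound 2 to compound 4 (0.10 log units; within the scatter), that is, none clearly beyond the scatter. Compound 4 is therefore expected at about 1500 nM, within 500 nM to 4500 nM.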

Compound 4, half-maximal inhibitory concentration: 410 nM
For compound 4 the middle estimate is 3.7-fold (0.56 log units) above the measured one; the measured number lies below the stated range.
By their numbers in this assay, from the lowest: compound 4; then compound 2; then compounds 1 and 3 (each within the scatter of the next).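

In this assay, phenylsulfanyl in place of phenethyl on an aromatic carbon meta to a large group gives a 2.9-fold lower number from compound 2 to compound 4 (0.47 log units; beyond the scatter), showing that the number responds to the group at this position. Both groups carry one six-membered aromatic ring of carbon only, so the step goes with a change in what joins that ring to the core, not in the ring itself. No measurement here explains the step.

The compounds shown leave open whether the sulfur or the shorter link matters, which a phenoxy or benzyl group at this position would help separate. From the compounds shown here alone, how an amine or a carboxylic acid on the outer ring would read also remains open.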